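The source may hold more compounds than are shown below. What is called first, only, known or untested is meant among the compounds shown, and "the series" means these compounds.

In a functional assay on trachea (Cavia porcellus) (a higher number here means a weaker inhibitor, a lower number a stronger inhibitor), compound 2 `CCCN1CC[C@@]2(OC)OC(N)=C(C#N)[C@@H](c3ccc(Cl)cc3)[C@@H]2C1` gives 30300 nM, the highest of the three numbers in hand. Compound 1 `CCN1CC[C@@]2(OC)OC(N)=C(C#N)[C@@H](c3ccc(Cl)cc3)[C@@H]2C1` gives 14900 nM and compound 3 `CO[C@@]12CCN(Cc3ccccc3)C[C@H]1[C@H](c1ccc(Cl)cc1)C(C#N)=C(N)O2` gives 18500 nM; the step of a 2.0-fold higher number from compound 1 to compound 2 (0.31 log units; beyond the scatter) is modest, while a 1.2-fold higher number from compound 1 to compound 3 (0.09 log units; within the scatter) and a 1.6-fold lower number from compound 2 to compound 3 (0.21 log units; within the scatter) stay within the scatter. Compound 4 `CCCN1CC[C@@]2(OC)OC(N)=C(C#N)[C@@H](c3ccc(Cl)cc3Cl)[C@@H]2C1` differs from compound 2 by chloro in place of hydrogen on an aromatic carbon. All three measured steps alter only the group bound to the amine nitrogen in a ring, and none touches the 4-chlorophenyl group; a direct guide for this change is lacking. Compound 4 is therefore expected to show a step of a 1.2-fold lower number from compound 2 to compound 4 (0.08 log units; within the scatter) that does not reach beyond the scatter. Compound 4 is estimated at 25000 nM, within a range of 8000 nM to 80000 nM.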

Compound 4, half-maximal inhibitory concentration: 35500 nM
Compound 4: middle estimate off by 1.4-fold (0.15 log units), on the low side; measured number inside the range.
By their numbers in this assay, from the lowest: compounds 1, 3, 2 and 4 (each within the scatter of the next, the first and the last beyond it).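

In this assay, chloro in place of hydrogen on an aromatic carbon, which turns 4-chlorophenyl into 2,4-dichlorophenyl, gives a 1.2-fold higher number from compound 2 to compound 4 (0.07 log units; within the scatter). This is the only change shown on the aromatic ring rather than on the group bound to the amine nitrogen, and at this place, ortho to a large group, the added chloro leaves compound 4 not distinguishable from compound 2. Nothing measured beyond these numbers bears on this result.

On these data alone, whether a larger group at this place, such as methoxy or trifluoromethyl, would give a step beyond the scatter stays open. So does the effect of an amine on this aromatic ring.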